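Aryl Ring Swaps on a Furan Amidine Scaffold

This account rests on a few compounds, and the source may have more. Where it says the series, first, only, none or still open, it means among the compounds named here.

Measured compounds:
compound 1: `Cc1ccc(-c2ccc(-c3ccc(C(=N)N)cc3)o2)cc1`, 72 nM
compound 2: `N=C(N)c1ccc(-c2ccc(-c3cccc(F)c3)o2)cc1`, 98 nM

In an assay on isolated protein for inhibition of ribosyldihydronicotinamide dehydrogenase [quinone] (Homo sapiens), read by spectrophotometry, with a stated time of 1 min, in the absence of a further agent (a lower number here means a stronger inhibitor, a higher number a weaker inhibitor), compound 1 gives 72 nM, and in this assay compound 2 gives 98 nM. Going by the values given here, compound 2 has only one measured neighbour, and the move a 1.4-fold higher number from compound 1 to compound 2 (0.13 log units; within the scatter) shows that the two numbers cannot be told apart. Compound 3 is `N=C(N)c1ccc(-c2ccc(-c3ccc(Br)cc3)o2)cc1`. The change from compound 2 to compound 3 is 4-bromophenyl in place of 3-fluorophenyl on an aromatic carbon; the group sits on an aromatic carbon of a five-membered aromatic ring with one oxygen, next to the ring oxygen. Among the compounds with values here, the only step that bears on this is the one from compound 1 to compound 2, which was within the scatter; the expected step of a 1.2-fold lower number from compound 2 to compound 3 (0.06 log units; within the scatter) is therefore estimated to remain within the scatter as well. For compound 3 in this assay the estimate is 85 nM, with a range from 35 nM to 200 nM.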

Compound 3, half-maximal inhibitory concentration: 27 nM
For compound 3 the middle estimate is 3.1-fold (0.50 log units) above the measured one, and the stated range ends above it.
By their numbers in this assay, from the lowest: compound 3; then compounds 1 and 2 (each within the scatter of the next).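

In this assay, the aryl group on the aromatic carbon next to the ring oxygen now shows an effect that the earlier pair could not: the change to 4-bromophenyl gives a 3.6-fold lower number from compound 2 to compound 3 (0.56 log units; beyond the scatter), and bromo in place of methyl gives a 2.7-fold lower number from compound 1 to compound 3 (0.43 log units; beyond the scatter). Both steps are modest, but each lies beyond the scatter, so this position does respond to the choice of phenyl substituent, and 3-fluorophenyl and 4-bromophenyl differ here despite matching heavy-atom counts. Nothing available accounts for the gain in potency.

The step from 3-fluorophenyl to 4-bromophenyl alters both the halogen and its place on the phenyl ring, so the compounds shown cannot separate these two changes. On these data alone, whether 4-chlorophenyl, 3-bromophenyl or 4-aminophenyl would match 4-bromophenyl also remains open.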